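Hydrazide to methyl ester on the propanoyl chain of compound 1

The source may hold more compounds than are shown below. What is called first, only, known or untested is meant among the compounds shown, and "the series" means these compounds.

Compound 1 `NNC(=O)CCc1ccncc1-c1ccc2ccccc2c1` is the reference point of the series. In an assay on a protein complex for inhibition of CDK8/Cyclin C (Homo sapiens), with a stated time of 1 h (a lower number here means a stronger inhibitor, a higher number a weaker inhibitor), compound 1 gives 7.7 nM, the lowest of the two numbers reported in this set. Compound 3 `Cn1ncc2cc(-c3cnccc3/C=C/C(=O)N3CCOCC3)ccc21` carries a different aryl group and an unsaturated morpholine amide; in this assay compound 3 gives 356 nM, a markedly higher number than that of compound 1, a gap that lies beyond the usual scatter. Compound 2 `COC1CN(C(=O)/C=C/c2ccncc2-c2ccc(F)cc2)C1` belongs to the same series but has no numerical result in this assay, its entry reading "not determined" (no result reported).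

The step under consideration leads from compound 1 to compound 4 `COC(=O)CCc1ccncc1-c1ccc2ccccc2c1`. The change is methoxy in place of aminoamino on a carbonyl carbon: methoxy in place of aminoamino on the carbonyl carbon, whose other neighbour is a saturated chain carbon, so that the 2-(aminocarbamoyl)ethyl side chain becomes a 2-(methoxycarbonyl)ethyl side chain. Within the data shown here, no directly comparable pair of measured compounds exists in this set, so the size of the step is open. The two hydrogen-bond donors that leave are not replaced, and the expectation is a moderate rise in the number, that is a weaker inhibitor, of a 3.9-fold higher number from compound 1 to compound 4 (0.59 log units; beyond the scatter). Compound 4 is therefore estimated at 30 nM, with a range from 8 nM to 120 nM.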

Compound 4, half-maximal inhibitory concentration: 259 nM
For compound 4 the middle estimate is 8.6-fold (0.94 log units) below the measured one; measured number outside the range, above it.
By their numbers in this assay, from the lowest: compound 1; then compounds 4 and 3 (each within the scatter of the next).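

Read in this assay the exchange of aminoamino for methoxy on the carbonyl carbon gives a 34-fold higher number from compound 1 to compound 4 (1.53 log units; beyond the scatter) and so provides the first comparison in this set in which only one place differs. With the core of compound 1 unchanged and the same count of heavy atoms in the group that leaves and the group that enters, the end of the 2-(aminocarbamoyl)ethyl side chain proves to be a place where the number responds strongly; the hydrogen-bond donors of aminoamino leave, none enters, and the hydrogen-bond acceptor count stays the same. No measurement at hand bears on the origin of this step.

Still open, from the compounds shown here alone, is whether a primary amide, a methylamide or a carboxylic acid on the same carbonyl carbon would give a number closer to that of compound 1 or to that of compound 4. Also open, going by these compounds, is whether a shorter or longer chain carrying the aminocarbamoyl group would hold the low number of compound 1, and whether the same exchange has a step of similar size on other aryl groups.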